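Replacing the ring nitrogen of compound 2 with an oxygen

The source may hold more compounds than are shown below. What is called first, only, known or untested is meant among the compounds shown, and "the series" means these compounds.

Measured compounds:
Compound 1 `Cc1cc(OC[C@@H]2CN(C)c3ccccc3O2)ccc1C(=O)Nc1cc(CC(=O)O)ccc1Cl`: "not determined" (no result reported) in a functional assay on CHO cells for antagonist activity at prostaglandin D2 receptor (Mus musculus), read by cAMP accumulation and immunoassay, with a stated time of 10 min; on this read-out lower numbers stand for stronger inhibition and higher numbers for weaker inhibition
Compound 2 `Cc1cc(OC[C@@H]2CN(C)c3ccccc3O2)cc(C)c1C(=O)Nc1cc(CC(=O)O)ccc1Cl`: 7.6 nM

Compound 1 carries a single methyl on the aryl ether ring, and in this assay compound 1 is recorded as "not determined" (no result reported), with no number reported. Going by the values given here, compound 2, with two methyls on that ring, is the only compound with a measured value: in this assay compound 2 gives 7.6 nM, so it is the sole reference point and no comparison between measured compounds can be drawn.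

Compound 3 `Cc1cc(OC[C@@H]2COc3ccccc3O2)cc(C)c1C(=O)Nc1cc(CC(=O)O)ccc1Cl` differs from compound 2 in one place: a group of 10 heavy atoms (8 carbon, 2 oxygen; one six-membered non-aromatic ring with 2 hetero atoms, one six-membered aromatic ring of carbon only) in place of a group of 11 heavy atoms (9 carbon, 1 nitrogen, 1 oxygen; one six-membered non-aromatic ring with 2 hetero atoms, one six-membered aromatic ring of carbon only), on a saturated chain carbon bound to an oxygen on an aromatic ring. The group that leaves holds a ring nitrogen bearing a methyl; the group that enters holds a second ring oxygen instead, while the rest of the molecule, including the acid-bearing anilide, is unchanged.

Among the compounds with values here, with no measured step of this kind available, the expected change is small, and the estimated step of a 1.8-fold higher number from compound 2 to compound 3 (0.27 log units; within the scatter) is taken to lie within the usual scatter or slightly toward weaker inhibition. Compound 3 is therefore expected to give about 14 nM in this assay, within a range of 4 nM to 50 nM.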

Compound 3, half-maximal inhibitory concentration: 4.3 nM
The estimate for compound 3 lay 3.3-fold (0.51 log units) above the measured number, and the stated range covers the measured number.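

In this assay, exchanging the ring nitrogen bearing a methyl for a second ring oxygen gives a 1.8-fold lower number from compound 2 to compound 3 (0.25 log units; within the scatter), a step within the usual scatter, so the two compounds cannot be told apart on this read-out. Going by these compounds alone, this is the first comparison between measured compounds, and it shows that, with the two methyls on the aryl ether ring and the acid-bearing anilide held constant, the group on the saturated chain carbon bound to an oxygen on an aromatic ring can be either the methyl-bearing nitrogen ring or 2,3-dihydro-1,4-benzodioxin-2-yl without a change beyond the scatter. Nothing available accounts for this result or says how the two groups compare in any other respect.

What the compounds shown leave open is how far this holds for other atoms at that ring place, such as a ring sulfur, a ring nitrogen bearing a hydrogen or one bearing a longer chain such as benzyl. They also give no reading of what the second methyl on the aryl ether ring contributes, or of the opposite configuration at the defined stereocentre.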